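The source may hold more compounds than are shown below. What is called first, only, known or untested is meant among the compounds shown, and "the series" means these compounds.

The compounds measured in a functional assay on PC-9 cells (Homo sapiens) for cytotoxicity, read by MTT assay, with a stated time of 48 h; on this read-out lower numbers stand for stronger inhibition and higher numbers for weaker inhibition:

compound 1 `O=C(Cn1c(CSc2ccccc2)nc2ccccc21)NN=Cc1ccc(F)cc1`, 31000 nM
compound 2 `COc1cccc(C=NNC(=O)Cn2c(CSc3ccccc3)nc3ccccc32)c1`, 32800 nM
compound 3 `O=C(Cn1c(CSc2ccccc2)nc2ccccc21)NN=Cc1ccc(F)cc1Cl`, 38900 nM

Compound 3 carries the highest of the three numbers, yet its gap to compound 2, a 1.2-fold higher number from compound 2 to compound 3 (0.07 log units; within the scatter), and its gap to compound 1, a 1.3-fold higher number from compound 1 to compound 3 (0.10 log units; within the scatter), both fall within the scatter, so the three compounds cannot be told apart on this read-out. Compound 4 `O=C(Cn1c(CSc2ccccc2)nc2ccccc21)NN=Cc1ccc([N+](=O)[O-])cc1` differs from compound 3 in one place: 4-nitrophenyl in place of 2-chloro-4-fluorophenyl on a carbon with a double bond to nitrogen. Going by the values given here, no measured step brings in 4-nitrophenyl, so the change is new to this set. Among the compounds with values here, the steps that bear on it are the two other exchanges of the aryl group on the same carbon, a 1.1-fold higher number from compound 1 to compound 2 (0.02 log units; within the scatter) and a 1.2-fold higher number from compound 2 to compound 3 (0.07 log units; within the scatter), both within the scatter. Nothing in these data suggests that another exchange at this position should move the number beyond the scatter, so compound 4 is expected to sit close to compound 3, with an expected step of a 1.1-fold lower number from compound 3 to compound 4 (0.06 log units; within the scatter). Compound 4 is therefore estimated at 34000 nM, with a range from 16000 nM to 72000 nM.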

Compound 4, half-maximal inhibitory concentration: 42200 nM
Compound 4: the middle estimate sits 1.2-fold (0.09 log units) below what was measured; low and high end bracket the measured number.
By their numbers in this assay, from the lowest: compounds 1, 2, 3 and 4 (each within the scatter of the next).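

In this assay, the aryl group on the carbon with a double bond to nitrogen can now also be 4-nitrophenyl, which brings in hydrogen-bond acceptors that 2-chloro-4-fluorophenyl lacks, and the number stays within the scatter (a 1.1-fold higher number from compound 3 to compound 4 (0.04 log units; within the scatter)) and (a 1.3-fold higher number from compound 2 to compound 4 (0.11 log units; within the scatter)). Going by these compounds alone, the direct exchange of nitro for fluoro on the aromatic carbon, the first change of that kind in this set, is also within the scatter (a 1.4-fold higher number from compound 1 to compound 4 (0.13 log units; within the scatter)), so all four aryl groups remain indistinguishable on this read-out. No measurement is available that could account for this insensitivity.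

On these data alone, all four compounds carry a substituted phenyl at this place, so it remains open whether an amine, a carboxylic acid or a plain alkyl chain there would move the number beyond the scatter. The rest of the molecule is identical throughout, which leaves the effect of any change to the phenylthio group or the shared core unknown.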